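The source may report more compounds than this note shows. Statements on the series, on what has been measured and on what is new or still open speak of the compounds shown alone.

In a functional assay on MDA-MB-231 cells (Homo sapiens) for inhibition, read by MTT assay, with a stated time of 72 h (a higher number here means a weaker inhibitor, a lower number a stronger inhibitor), the series reads as follows:

compound 1 `Nc1nc2cc(-c3nn(CCCCC(=O)NO)c4ncnc(N)c34)ccc2o1`: 21200 nM
compound 2 `Nc1nc2cc(-c3nn(CCCCCC(=O)NO)c4ncnc(N)c34)ccc2o1`: 19000 nM
compound 3 `Nc1nc2cc(-c3nn(CCCCCCCCC(=O)NO)c4ncnc(N)c34)ccc2o1`: not yet measured

Compound 2 stands level with compound 1 within the scatter, so the two cannot be ranked. The change from compound 2 to compound 3 is 3-(hydroxycarbamoyl)propyl in place of hydroxycarbamoyl on a saturated chain carbon, five bonds along the chain from an aromatic nitrogen and it falls on a saturated chain carbon, five bonds along the chain from an aromatic nitrogen.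

For the measured compounds named here, only one measured step bears on this. The step of a 1.1-fold lower number from compound 1 to compound 2 (0.05 log units; within the scatter) lies within the scatter and comes from (hydroxycarbamoyl)methyl in place of hydroxycarbamoyl. It is a single observation on a smaller extension than the one now made, so it cannot show whether the flat behaviour persists further along the chain. No step beyond the scatter is therefore expected in this assay, though the margin stays wide in both directions. The estimated step is a 1.4-fold lower number from compound 2 to compound 3 (0.13 log units; within the scatter) and no larger shift is expected. Compound 3 is expected at 14000 nM within a range of 5000 nM to 35000 nM on this reasoning.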

Compound 3, half-maximal inhibitory concentration: 30300 nM
For compound 3 the middle estimate is 2.2-fold (0.34 log units) below the measured one; the range from low to high includes it.
By their numbers in this assay, from the lowest: compounds 2, 1 and 3 (each within the scatter of the next).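

In this assay the chain can now be read over a much larger extension than before: 3-(hydroxycarbamoyl)propyl in place of hydroxycarbamoyl on a saturated chain carbon, five bonds along the chain from an aromatic nitrogen, gives a 1.6-fold higher number from compound 2 to compound 3 (0.20 log units; within the scatter) and 4-(hydroxycarbamoyl)butyl in place of hydroxycarbamoyl, four bonds along the chain from an aromatic nitrogen, gives a 1.4-fold higher number from compound 1 to compound 3 (0.16 log units; within the scatter). The flat reading, which had rested on one small extension, therefore holds across all three compounds, and no chain length among them can be ranked against another at this position. Nothing in hand accounts for this flat response.

The compounds shown leave open whether a shorter chain, an amine within the chain, or a carboxylic acid in place of the terminal hydroxycarbamoyl would give a step beyond the scatter in this assay at this position. From the compounds shown here alone, whether a change on the shared core, rather than on the chain, would do so also stays open.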